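A few compounds are considered here, and "the series" means these few. Any claim that something is new, unique, unknown or untested is made for them only; others in the source may bear on it.

Compound 3 `COc1cc2ncnc(NCc3cccc(NC(=O)Nc4ccc(C)cc4)c3)c2cc1OC` gives 34200 nM in a functional assay on MGC-803 cells (Homo sapiens) for antiproliferative activity, read by MTT assay; a higher number here means a weaker inhibitor, a lower number a stronger inhibitor. Compound 1 `Cc1ccc(NC(=O)Nc2cccc(CNc3ncnc4ccccc34)c2)cc1` gives 31200 nM and compound 2 `O=C(Nc1cccc(Cl)c1)Nc1cccc(CNc2ncnc3ccccc23)c1` gives 19200 nM, so none of the three separates from another beyond the scatter. For the measured compounds named here, only one single-point change is measured, a 1.6-fold lower number from compound 1 to compound 2 (0.21 log units; within the scatter), which replaces the aryl group on the amide-type nitrogen and stays within the scatter. Compound 4 `COc1cc2ncnc(NCc3cccc(NC(=O)Nc4ccc([N+](=O)[O-])cc4)c3)c2cc1OC` differs from compound 3 by nitro in place of methyl on an aromatic carbon. Going by the values given here, the step from compound 1 to compound 2 bears on this only loosely, since it alters the same aryl group but to a different substituent; no measured step introduces a nitro. The expected step is therefore a 1.0-fold lower number from compound 3 to compound 4 (0.00 log units; within the scatter), with no change beyond the scatter. Compound 4 is estimated at 34000 nM, in the range 15000 nM to 80000 nM.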

Compound 4, half-maximal inhibitory concentration: 8120 nM
Beside the measured number, compound 4's estimate is 4.2-fold (0.62 log units) above it; measured number below the stated range.
By their numbers in this assay, from the lowest: compound 4; then compounds 2, 1 and 3 (each within the scatter of the next).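

In this assay, going from 4-methylphenyl to 4-nitrophenyl gives a 4.2-fold lower number from compound 3 to compound 4 (0.62 log units; beyond the scatter), so a change at this aryl substituent can move the number beyond the scatter, which a 1.6-fold lower number from compound 1 to compound 2 (0.21 log units; within the scatter) did not show. The change puts nitro, with its two hydrogen-bond acceptors, in place of methyl, which has none, on an aromatic carbon para to a large group. No measurement here accounts for the step.

From the compounds shown here alone, whether the step is specific to nitro remains open, and an amine or a nitrile at this position would bear on that. Also open, going by these compounds, is whether nitro gives a similar step on the core of compound 1.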